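The source may report more compounds than this note shows. Statements on the series, on what has been measured and on what is new or still open speak of the compounds shown alone.

Measured compounds:
compound 1, `COc1cc(CN(C(=O)CSc2nc3ccccc3s2)c2cc(OC)c(OC)c(OC)c2)cc(OC)c1OC` — 65300 nM
compound 2, `COc1ccc(CN(C(=O)CSc2nc3cc(Cl)ccc3s2)c2cc(OC)c(OC)c(OC)c2)cc1O` — 429 nM

Compound 1 `COc1cc(CN(C(=O)CSc2nc3ccccc3s2)c2cc(OC)c(OC)c(OC)c2)cc(OC)c1OC` and compound 2 `COc1ccc(CN(C(=O)CSc2nc3cc(Cl)ccc3s2)c2cc(OC)c(OC)c(OC)c2)cc1O` were both tested in a functional assay on HCT-116 cells (Homo sapiens) for antiproliferative activity, read by MTT assay, with a stated time of 48 h; on this read-out higher numbers stand for weaker inhibition and lower numbers for stronger inhibition. In this assay, within the data shown here, compound 1 gives 65300 nM, the highest of the two numbers, while compound 2 gives 429 nM, a far lower number that lies well beyond the scatter; these two compounds differ in more than one place, so their values are only set side by side here and no single step is drawn from them.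

Compound 3 `COc1cc(N(Cc2ccc(Br)cc2)C(=O)CSc2nc3ccccc3s2)cc(OC)c1OC` is not yet measured. It differs from compound 1 in one place: 4-bromophenyl in place of 3,4,5-trimethoxyphenyl on a saturated chain carbon bound to an amide-type nitrogen. The shared core of compound 1 is otherwise kept.

Among the measured compounds shown here, with no measured pair that isolates this change, the expectation for compound 3 rests on compound 1 alone, with compound 2 only hinting that a lighter group on that chain carbon can go with a lower number. The step from compound 1 to compound 3 is expected to be moderate and toward a lower number, a 5.4-fold lower number from compound 1 to compound 3 (0.74 log units; beyond the scatter). Compound 3 is therefore estimated at 12000 nM, with a range from 2500 nM to 60000 nM.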

Compound 3, half-maximal inhibitory concentration: 63800 nM
Beside the measured number, compound 3's estimate is 5.3-fold (0.73 log units) below it; measured number above the stated range.
By their numbers in this assay, from the lowest: compound 2; then compounds 3 and 1 (each within the scatter of the next).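

In this assay, among these compounds, the earlier compounds offered no single step at this place, and the exchange of 3,4,5-trimethoxyphenyl for 4-bromophenyl on a saturated chain carbon bound to an amide-type nitrogen now supplies one: a 1.0-fold lower number from compound 1 to compound 3 (0.01 log units; within the scatter). With the shared core of compound 1 kept, a group of 12 heavy atoms with 3 hydrogen-bond acceptors and a group of 7 heavy atoms with 0 hydrogen-bond acceptors therefore give numbers that cannot be told apart on this read-out, so neither the methoxy groups nor the bromine sets one of these two compounds apart from the other here. No measurement shown explains why the two groups read alike.

Among the compounds shown here, this single step covers only two aryl groups at this place on one core, so it cannot show whether the same exchange would read alike on a different core. Also open, as far as these compounds go, is whether a phenyl ring carrying an amine or a carboxylic acid at this place, or a longer chain between the amide-type nitrogen and the ring, would move the number beyond the scatter.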